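Nitrofuran amide series: nitro replaces trifluoromethyl on MRC5 cells

The compounds below may be only part of what the source reports. "The series", "measured", "known", "first", "only" and "open" are said of these compounds alone.

Compound 2 `O=C(NCc1cn(Cc2ccc(C(F)(F)F)cc2)nn1)c1ccc([N+](=O)[O-])o1` and compound 1 `COc1ccc(Cn2cc(CNC(=O)c3ccc([N+](=O)[O-])o3)nn2)cc1F` share one core and differ only in the group on the six-membered aromatic ring of carbon only. In an ADME assay on MRC5 cells (Homo sapiens) for cytotoxicity (a higher number here means a weaker inhibitor, a lower number a stronger inhibitor), compound 2 gives 321000 nM, and in this assay compound 1 gives 324000 nM; the two numbers lie within the scatter of each other, so neither stands apart. Compound 3 `O=C(NCc1cn(Cc2ccc([N+](=O)[O-])cc2)nn1)c1ccc([N+](=O)[O-])o1` is not yet measured and differs from compound 2 by nitro in place of trifluoromethyl on an aromatic carbon. Within the data shown here, no measured pair shows what this swap does here, and the two measured compounds agree despite different groups at that place. For compound 3 the expected step is a 1.0-fold lower number from compound 2 to compound 3 (0.00 log units; within the scatter), that is, none beyond the scatter. Compound 3 is expected to give about 320000 nM in this assay, estimated between 150000 nM and 650000 nM.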

Compound 3, half-maximal inhibitory concentration: 213000 nM
The estimate for compound 3 lay 1.5-fold (0.18 log units) above the measured number; the range from low to high includes it.
By their numbers in this assay, from the lowest: compounds 3, 2 and 1 (each within the scatter of the next).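

In this assay, among these compounds, nitro in place of trifluoromethyl on an aromatic carbon para to a large group gives a 1.5-fold lower number from compound 2 to compound 3 (0.18 log units; within the scatter) and so, in the first direct reading of this swap, stays within the scatter. Replacing the whole 3-fluoro-4-methoxyphenyl with 4-nitrophenyl gives a 1.5-fold lower number from compound 1 to compound 3 (0.18 log units; within the scatter) and likewise does not separate the compounds. No data on hand bear on a cause for these readings. On these data alone, whether an amine or a carboxylic acid at this place would shift the number beyond the scatter remains open. Also open, as far as these compounds go, is how changes to the shared core would read.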